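Rigidifying the linker of a tetrahydroisoquinoline-based chemokine receptor ligand

This account rests on a few compounds, and the source may have more. Where it says the series, first, only, none or still open, it means among the compounds named here.

The study measures agonist activity in a functional assay on cells for agonist activity at C-X-C chemokine receptor type 4 (Homo sapiens), read by fluorescence and calcium flux, with a stated time of 90 s; on this read-out lower numbers stand for an effect already at smaller amounts and higher numbers for an effect only at larger amounts of compound. Of the compounds shown here, three have been tested. Compound 1 `c1ccc(CN(CCCCN(C[C@H]2Cc3ccccc3CN2)[C@H]2CCCc3cccnc32)Cc2ccccc2)cc1` reaches only the limit of this assay, at > 30000 nM. Compound 3 `c1ccc2c(c1)CN[C@@H](CN(Cc1ccc(CNCc3ccncc3)cc1)[C@H]1CCCc3cccnc31)C2` likewise gives only a limit, > 30000 nM. Compound 2 `c1ccc2c(c1)CN[C@@H](CN(CCCCNCC1CCOCC1)[C@H]1CCCc3cccnc31)C2` stands with them, as it too shows only a limit, > 30000 nM. Thus every measured value sits at the same edge, as summarised by the limit of > 30000 nM in this assay, at which 3 of the 3 values shown sit, and no ordering among compounds 1, 2 and 3 can be drawn from these numbers.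

Compound 4 `C(=C/CN(C[C@H]1Cc2ccccc2CN1)[C@H]1CCCc2cccnc21)\CNCC1CCOCC1` differs from compound 2 by a group of 11 heavy atoms (9 carbon, 1 nitrogen, 1 oxygen; one six-membered non-aromatic ring with 1 hetero atom) in place of a group of 11 heavy atoms (9 carbon, 1 nitrogen, 1 oxygen; one six-membered non-aromatic ring with 1 hetero atom), on a saturated chain carbon bound to an amine nitrogen. Among the measured compounds shown here, no step between measured compounds is available to weigh this change. Since compound 2 gives only a limit, the step from compound 2 to compound 4 cannot be computed; the expected step that the limit leaves unreadable from compound 2 to compound 4 is therefore an expectation that compound 4 remains near the same edge. Compound 4 is estimated at 40000 nM, with a range from 8000 nM to 200000 nM, and the result is expected most likely to be reported as a limit again.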

Compound 4, half-maximal effective concentration: > 30000 nM
Compound 4: a limit, no number (the forecaster's own chance of this, stated with the estimate: 85%); the middle value lies beyond the limit too.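

Among the compounds shown here, compound 2 and compound 4 both give only a limit in this assay and so no step between them can be read: the limit of > 30000 nM in this assay, at which 4 of the 4 values shown sit. The compounds shown leave open whether the double bond in compound 4 alters agonist activity at all, and which structure would give a measurable value.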